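A Halogen-Bearing Arylamine Replaces the Methylphenyl Group

A few compounds are considered here, and "the series" means these few. Any claim that something is new, unique, unknown or untested is made for them only; others in the source may bear on it.

Of the compounds shown here, three have been measured in a functional assay on BGC-823 cells (Homo sapiens) for cytotoxicity, read by MTT assay; on this read-out higher numbers stand for weaker inhibition and lower numbers for stronger inhibition. Compound 1 `COc1cc(/C=C/C(=O)c2sc(Nc3ccccc3C)nc2C)cc(OC)c1OC` stands lowest of the three, giving 5400 nM in this assay. Compound 2 `Cc1cccc(Nc2nc(C)c(C(=O)/C=C/c3ccccc3)s2)c1` gives 13600 nM, and compound 3 `COc1cccc(/C=C/C(=O)c2sc(Nc3ccccc3)nc2C)c1` gives 14300 nM; both of these numbers lie beyond the usual scatter from that of compound 1, so compound 1 is the strongest inhibitor among the three. For the measured compounds named here, compound 2 and compound 3 differ from one another in more than one place and from compound 1 in more than one place, so no single structural step between measured compounds can be read from them.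

Compound 4 `COc1cc(/C=C/C(=O)c2sc(Nc3ccc(F)c(Cl)c3)nc2C)cc(OC)c1OC` has not yet been measured. It differs from compound 1 in one place only: 3-chloro-4-fluorophenyl in place of 2-methylphenyl on a nitrogen on an aromatic ring. The rest of the molecule, including the three methoxy groups of compound 1, is kept.

The measured set holds no change at this nitrogen. The expected step is modest and could fall in either direction: the estimate is a 1.4-fold lower number from compound 1 to compound 4 (0.13 log units; within the scatter), a small gain in inhibition that may well stay within the scatter. Compound 4 is therefore expected to give about 4000 nM in this assay, with a likely range from 1500 nM to 12000 nM.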

Compound 4, half-maximal inhibitory concentration: 9700 nM
The estimate for compound 4 lay 2.4-fold (0.38 log units) below the measured number, within the range that was stated.
By their numbers in this assay, from the lowest: compounds 1, 4, 2 and 3 (each within the scatter of the next, the first and the last beyond it).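

For the compounds shown here, this is the first comparison that isolates the group on this nitrogen: in this assay the replacement of 2-methylphenyl by 3-chloro-4-fluorophenyl gives a 1.8-fold higher number from compound 1 to compound 4 (0.25 log units; within the scatter) and so does not separate the two compounds. With the three methoxy groups kept, the methyl-bearing ring on this nitrogen can therefore give way to a ring bearing chlorine and fluorine without a step beyond the usual scatter, although this rests on a single pair and sets no trend for other arylamines. No supporting measurement is available that would explain this result.

The compounds shown leave open whether chlorine or fluorine alone on the phenyl ring would give a different number from the two together, and whether the result would hold with the methyl group of compound 1 moved elsewhere on that ring. They also leave open whether this nitrogen tolerates something other than a substituted phenyl ring, such as a pyridine ring, a cyclohexyl group or a phenyl ring carrying a carboxylic acid.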